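The source may hold more compounds than are shown below. What is called first, only, known or untested is meant among the compounds shown, and "the series" means these compounds.

Measured compounds:
Compound 1, `COc1cc(C2=NN(C(C)=O)C(c3ccc([N+](=O)[O-])cc3)O2)cc(OC)c1OC`: 4200 nM
Compound 2, `COc1cc(C2=NN(C(C)=O)C(c3ccccc3)O2)cc(OC)c1OC`: 6400 nM
Compound 3, `COc1ccc(C2=NN(C(C)=O)C(c3ccc(OC)c([N+](=O)[O-])c3)O2)cc1`: only a limit in a functional assay on L1210 cells (Mus musculus) for antiproliferative activity, read by MTT assay, with a stated time of 72 h; a lower number here means a stronger inhibitor, a higher number a weaker inhibitor

In this assay compound 1 gives 4200 nM and compound 2 gives 6400 nM. Compound 1 and compound 2 differ by hydrogen in place of nitro on an aromatic carbon, a change that gave a 1.5-fold higher number from compound 1 to compound 2 (0.18 log units; within the scatter). For compound 3 this assay reports only a limit, > 100000 nM, a limit of the assay and not a number, as noted in the limit of > 100000 nM in this assay, at which 1 of the 3 values shown sits. The difference between the core of compound 3 and the core of compound 1 is not broken down here. Compound 4, `COc1ccc(C2=NN(C(C)=O)C(c3ccc(OC)cc3)O2)cc1`, is not yet measured; it differs from compound 3 by hydrogen in place of nitro on an aromatic carbon. This is the same kind of change as that from compound 1 to compound 2, but the place differs: there it sat para to a large group, here ortho to a methoxy group and meta to a large group. Since compound 3 gave only a limit, compound 4 is expected to stay weak, with an estimated step that the limit leaves unreadable from compound 3 to compound 4. The estimate for compound 4 is 120000 nM, between 40000 nM and 400000 nM.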

Compound 4, half-maximal inhibitory concentration: > 100000 nM
Compound 4: only a limit was reported; the forecaster's own chance of this, stated with the estimate: 60%; the middle value does not contradict the limit.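

No step can be read between compound 3 and compound 4, because each of the two reports only a limit of the assay and not a number: the limit of > 100000 nM in this assay, at which 2 of the 4 values shown sit.

The compounds shown leave open whether hydrogen in place of nitro changes activity on the core of compound 3, and how that core compares with the core of compound 1.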